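Compound 3: furan-2-yl replaced by 4-methoxyphenyl

A few compounds are considered here, and "the series" means these few. Any claim that something is new, unique, unknown or untested is made for them only; others in the source may bear on it.

Measured in a functional assay on THP-1 cells (Homo sapiens) for inhibition, read by sulforhodamine B assay, with a stated time of 48 h, tested at 50 uM; a higher number here means more inhibition of growth at the concentration tested, a lower number less inhibition of growth:
- compound 1 `COc1cc(/C=C/C(=O)/C=C/c2cccc3ccccc23)ccc1OCc1cn(CCOc2cc(=O)oc3ccccc23)nn1`: 89%
- compound 2 `COc1cc(/C=C/C(=O)/C=C/c2ccco2)ccc1OCc1cn(CCCCOc2cc(=O)oc3ccccc23)nn1`: 49%

Compound 2 holds the lower of the two numbers, and the gap up to compound 1 lies beyond the usual scatter. These two compounds differ in more than one place, so their gap cannot be assigned to any single structural change.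

The next compound, compound 3 `COc1ccc(/C=C/C(=O)/C=C/c2ccc(OCc3cn(CCCCOc4cc(=O)oc5ccccc45)nn3)c(OC)c2)cc1`, has not yet been measured. It departs from compound 2 at one place: 4-methoxyphenyl in place of furan-2-yl on a double-bonded chain carbon bound to a double-bonded chain carbon. The new 4-methoxyphenyl sits on a double-bonded chain carbon bound to a double-bonded chain carbon, where furan-2-yl stood.

Among the measured compounds shown here, no measured pair isolates this change, so the expectation is a matter of judgement, framed only by compound 2 at 49% and compound 1 at 89%. A modest rise in this assay is expected, close to the edge of the scatter, and no change at all would not be surprising. The expected step is a number 13 percentage points higher from compound 2 to compound 3 (beyond the scatter). For compound 3 the estimated value is 62%, with an expected range of 41% to 83%.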

Compound 3, percent growth inhibition at one concentration: 45%
For compound 3 the middle estimate is 17 percentage points above the measured one, within the range that was stated.
By their numbers in this assay, from the lowest: compounds 3 and 2 (each within the scatter of the next); then compound 1.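

On a double-bonded chain carbon bound to a double-bonded chain carbon, 4-methoxyphenyl in place of furan-2-yl reads in this assay as a number 4 percentage points lower from compound 2 to compound 3 (within the scatter). Among the compounds shown here, this is the first comparison that isolates a single place, and it shows that this position takes a six-membered aromatic ring of carbon only, with 8 heavy atoms, in place of a five-membered aromatic ring with 1 hetero atom, with 5 heavy atoms, without a difference that stands clear of the scatter. No measurement at hand speaks to why these two groups read alike at this position.

Compound 1 differs from compound 2 and from compound 3 in more than one place, so its higher reading cannot yet be divided between its aromatic group and its linking chain. Also open, from the compounds shown here alone, is whether this position stays as flat for groups of another kind, such as a dimethylamino group or a carboxylic acid on the phenyl ring, since both groups compared here are uncharged aromatic rings.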